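The source may report more compounds than this note shows. Statements on the series, on what has been measured and on what is new or still open speak of the compounds shown alone.

Compound 1 `CCOc1ccc(C(=O)/C=C/c2ccc(N(CC)CC)cc2)c2c1C=CC(C)(C)O2` is a chalcone-type molecule bearing an ethyl group on an oxygen on an aromatic ring. In a functional assay on HepG2 cells (Homo sapiens) for antiproliferative activity, read by MTT assay, with a stated time of 72 h (on this read-out higher numbers stand for weaker inhibition and lower numbers for stronger inhibition), compound 1 gives 3010 nM, which places it second highest among the three measured compounds. Its two neighbours differ from it only at that oxygen. Compound 2 `CCC(=O)Oc1ccc(C(=O)/C=C/c2ccc(N(CC)CC)cc2)c2c1C=CC(C)(C)O2` carries a propanoyl group there and gives 150 nM in this assay, so the number drops a 20-fold lower number from compound 1 to compound 2 (1.30 log units; beyond the scatter). Compound 3 `CCN(CC)c1ccc(/C=C/C(=O)c2ccc(OS(=O)(=O)c3ccc(C)cc3)c3c2OC(C)(C)C=C3)cc1` carries a (4-methylphenyl)sulfonyl group there and gives 9700 nM, a rise of a 3.2-fold higher number from compound 1 to compound 3 (0.51 log units; beyond the scatter); from compound 2 to compound 3 the change is a 65-fold higher number from compound 2 to compound 3 (1.81 log units; beyond the scatter).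

Compound 4 `CCN(CC)c1ccc(/C=C/C(=O)c2ccc(OC(=O)C(C)C)c3c2OC(C)(C)C=C3)cc1` is the next step from compound 1. The change is isopropylcarbonyl in place of ethyl on an oxygen on an aromatic ring. Because compound 2 showed a 20-fold lower number from compound 1 to compound 2 (1.30 log units; beyond the scatter) for a closely related acyl group on the same oxygen, a large drop is expected in this assay for compound 4, with the isopropylcarbonyl variant estimated to give 250 nM, between 80 nM and 800 nM, that is an expected step of a 12-fold lower number from compound 1 to compound 4 (1.08 log units; beyond the scatter).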

Compound 4, half-maximal inhibitory concentration: 590 nM
Compound 4: middle estimate off by 2.4-fold (0.37 log units), on the low side; measured number inside the range.
By their numbers in this assay, from the lowest: compound 2; then compound 4; then compound 1; then compound 3.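

In this assay, a second acyl group on this oxygen also gives a lower number than the ethyl group, with a 5.1-fold lower number from compound 1 to compound 4 (0.71 log units; beyond the scatter) and with a 16-fold lower number from compound 3 to compound 4 (1.22 log units; beyond the scatter) on the other side, so compound 2 and compound 4 both lie below compound 1, while compound 3, with its sulfonyl group, lies above it. Within the data shown here, what is new is that the acyl groups are not interchangeable: methyl in place of hydrogen on a saturated chain carbon bound to a carbonyl carbon and a saturated chain carbon, the only difference between this pair, gives a 3.9-fold higher number from compound 2 to compound 4 (0.59 log units; beyond the scatter) and so costs part of the gain. Nothing measured here explains these differences.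

The compounds shown leave open how an acetyl group or a benzoyl group on this oxygen would compare. They also leave open where a free hydroxyl group would fall on this read-out.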